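A few compounds are considered here, and "the series" means these few. Any claim that something is new, unique, unknown or untested is made for them only; others in the source may bear on it.

Three compounds built on the same core, each carrying a small alkyl group on an aromatic nitrogen, were tested in a functional assay on HepG2 cells (Homo sapiens) for antiproliferative activity, read by CCK-8 assay, with a stated time of 72 h, tested at 8 uM; a higher number here means a stronger effect of the compound at the concentration tested, a lower number a weaker effect. Compound 1 `CC(C)n1cnc2c(Nc3ccccc3)nc(NCOCc3ccc(C(=O)Nc4ccccc4N)cc3)nc21` gives 50.2%. Compound 2 `CC(C)n1cnc2c(Nc3ccccc3)nc(NCOCc3ccc(/C=C/C(=O)Nc4ccccc4N)cc3)nc21` gives 40.8%. Compound 3 `CCCCn1cnc2c(Nc3ccccc3)nc(NCOCc3ccc(C(=O)Nc4ccccc4N)cc3)nc21` gives 70.7%. Of the three numbers, compound 2 has the lowest; its gap to compound 1 lies within the scatter, while its gap to compound 3 lies beyond it. The two measured steps point in different directions: a number 9.4 percentage points lower from compound 1 to compound 2 (within the scatter), whereas a number 20.5 percentage points higher from compound 1 to compound 3 (beyond the scatter).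

Compound 4 `Nc1ccccc1NC(=O)/C=C/c1ccc(COCNc2nc(Nc3ccccc3)c3ncn(C4CCCC4)c3n2)cc1` differs from compound 2 in one place: cyclopentyl in place of isopropyl on an aromatic nitrogen. Going by the values given here, this is a change at the same aromatic nitrogen that was altered between compound 1 and compound 3, so only that step bears directly on it. Because a number 20.5 percentage points higher from compound 1 to compound 3 (beyond the scatter) showed that a larger alkyl group on this nitrogen raised the read-out by a modest amount, a rise of similar size is expected when cyclopentyl replaces isopropyl, though a single step gives only a rough guide. The expected step is a number 15.2 percentage points higher from compound 2 to compound 4 (beyond the scatter). Compound 4 is therefore estimated at 56%, with a range from 38% to 74%.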

Compound 4, a percentage reported as inhibition, at one concentration (the size of the read-out at that concentration, not a potency): 18.8%
Compound 4: the middle estimate sits 37.2 percentage points above what was measured; measured number outside the range, below it.
By their numbers in this assay, from the lowest: compound 4; then compounds 2 and 1 (each within the scatter of the next); then compound 3.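

In this assay, the group on this aromatic nitrogen can lower the read-out as well as raise it: swapping isopropyl for cyclopentyl gives a number 22 percentage points lower from compound 2 to compound 4 (beyond the scatter). This runs opposite to a number 20.5 percentage points higher from compound 1 to compound 3 (beyond the scatter), so a group with more carbon at this position does not raise the number in every case shown. The two steps differ in two ways, as one brings in an open butyl chain and the other a five-membered ring, and one sits on compounds with the (2-aminophenyl)carbamoyl group while the other sits on compounds with the ethenyl-extended version of it; nothing available explains the fall in the number.

The compounds shown therefore cannot tell whether the drop belongs to the cyclopentyl ring itself or to its pairing with the ethenyl-extended group, a question that butyl on the ethenyl-extended compound and cyclopentyl on the other would help to settle. Also open, going by these compounds, is how other groups on this nitrogen would behave, such as a cyclopropyl ring or a longer chain like hexyl.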